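Methoxy for chloro on the aryl piperazine: cytotoxicity outlook

The compounds below may be only part of what the source reports. "The series", "measured", "known", "first", "only" and "open" are said of these compounds alone.

Measured compounds:
compound 1 `COc1cc(Cc2cnc(/N=C3\C(=O)N(CN4CCN(c5c(F)cc6c(=O)c(C(=O)O)cn(C7CC7)c6c5F)CC4C)c4ccc(Cl)cc43)nc2N)cc(OC)c1OC` — "not determined" (no result reported)
compound 2 `COc1cc(Cc2cnc(/N=C3\C(=O)N(CN4CCN(c5cccc(Cl)c5)CC4)c4ccc(Cl)cc43)nc2N)cc(OC)c1OC` — 39.2 ug/mL

For the measured compounds named here, compound 2 carries the only number in an ADME assay on MT4 cells (Homo sapiens) for cytotoxicity, read by MTT assay, with a stated time of 5 days (on this read-out higher numbers stand for lower toxicity in this test and lower numbers for higher toxicity in this test), where compound 2 gives 39.2 ug/mL; for compound 1 the test gives "not determined" (no result reported), so no comparison between the two can be drawn. Compound 3 `COc1cccc(N2CCN(CN3C(=O)/C(=N\c4ncc(Cc5cc(OC)c(OC)c(OC)c5)c(N)n4)c4cc(Cl)ccc43)CC2)c1` differs from compound 2 in one place: methoxy in place of chloro on an aromatic carbon. Going by the values given here, no step between two measured compounds is available to calibrate this change, and the shared core is otherwise unchanged. Given that compound 2 stands at 39.2 ug/mL, the exchange of a chloro for a methoxy on the aromatic carbon is not expected to move the read-out beyond the usual scatter, with an expected step from compound 2 to compound 3 of a 1.1-fold higher number from compound 2 to compound 3 (0.06 log units; within the scatter). Compound 3 is therefore estimated at 45 ug/mL, with a range from 20 ug/mL to 100 ug/mL.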

Compound 3, half-maximal cytotoxic concentration: 32.6 ug/mL
For compound 3 the middle estimate is 1.4-fold (0.14 log units) above the measured one; low and high end bracket the measured number.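

In this assay, the exchange of 3-chlorophenyl for 3-methoxyphenyl gives a 1.2-fold lower number from compound 2 to compound 3 (0.08 log units; within the scatter), the only step between measured compounds shown here. On this aromatic carbon, meta to a large group, the read-out therefore does not separate chloro from methoxy, even though methoxy brings one more heavy atom and a hydrogen-bond acceptor that chloro lacks. No measurement of any other property bears on this result.

From the compounds shown here alone, whether an amine, a carboxylic acid or a longer alkoxy chain on the same carbon would also stay within the scatter of compound 2 remains open, as does the same exchange elsewhere on that ring. Compound 1 gives "not determined" (no result reported), so it adds nothing to this question.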